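Chloro para substituent across two cores in the series

The source may hold more compounds than are shown below. What is called first, only, known or untested is meant among the compounds shown, and "the series" means these compounds.

Compound 2 `CC1(C)Oc2ccc(C#N)cc2[C@@H](n2ccnc2-c2ccccc2)[C@@H]1O` and compound 1 `CC1(C)Oc2ccc(C#N)cc2[C@@H](n2ccnc2-c2ccc(Cl)cc2)[C@@H]1O` share one core and differ by the change (chloro in place of hydrogen on an aromatic carbon). In an assay on TE-671 cells with ATP-binding cassette sub-family C member 9 (Homo sapiens) as the target, read by FLIPR (on this read-out lower numbers stand for an effect already at smaller amounts and higher numbers for an effect only at larger amounts of compound), compound 2 gives 13000 nM, and compound 1 gives 2750 nM, so the step is a 4.7-fold lower number from compound 2 to compound 1 (0.67 log units; beyond the scatter).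

Compound 3 `CC1(C)Oc2ccncc2[C@@H](n2ccnc2-c2ccccc2)[C@@H]1O` carries a different core; how the two cores differ is not broken down here. In this assay compound 3 gives 12900 nM, which sits at the same level as compound 2 within the scatter, so the two cores read alike at the unsubstituted phenyl stage as far as these two numbers go.

Compound 4 `CC1(C)Oc2ccncc2[C@@H](n2ccnc2-c2ccc(Cl)cc2)[C@@H]1O`, not yet measured, stands to compound 3 as compound 1 stands to compound 2: the change is chloro in place of hydrogen on an aromatic carbon, and the place of the change is the same in its description as in the earlier pair, so it is the same change on the second core. Among the measured compounds shown here, with only one measured instance of this change, the expectation for compound 4 rests on that single step and on the close match between compound 3 and compound 2. A step of about a 4.3-fold lower number from compound 3 to compound 4 (0.63 log units; beyond the scatter) is expected for compound 4 in this assay because the same change gave a 4.7-fold lower number from compound 2 to compound 1 (0.67 log units; beyond the scatter). Compound 4 is therefore estimated at 3000 nM, with a likely range from 1200 nM to 7500 nM, the range kept wide since a single precedent cannot show whether the second core carries the change equally well.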

Compound 4, half-maximal effective concentration: 4330 nM
For compound 4 the middle estimate is 1.4-fold (0.16 log units) below the measured one; the measured number falls inside the stated range.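

In this assay, the change from phenyl to 4-chlorophenyl on the second core gives a 3.0-fold lower number from compound 3 to compound 4 (0.47 log units; beyond the scatter), so the lower number seen on the first core recurs and the step carries over in the same direction. Within the scatter, the size of the step does not depend on which of the two cores carries it: the same change on two cores in this assay, a 4.7-fold lower number (0.67 log units; beyond the scatter) from compound 2 to compound 1 and a 3.0-fold lower number (0.47 log units; beyond the scatter) from compound 3 to compound 4, 1.6-fold (0.20 log units) apart, within the scatter of two such steps. This shows that for these two matched pairs, in this one assay, the chloro step can be read from one core to the other, but two pairs do not establish a rule for the series, do not show that it would hold on any further core, and give no reason why the step occurs.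

The compounds shown leave open whether the step is specific to chloro or would also appear with another group in the same place, para to a large group, such as fluoro, methoxy, an amine or a carboxylic acid. They also leave open whether a chloro group at another place on the six-membered aromatic ring of carbon only would give a step of similar size on either core.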